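Shortening the side chain by ethyl: compound 3 to compound 4

The source may report more compounds than this note shows. Statements on the series, on what has been measured and on what is new or still open speak of the compounds shown alone.

Measured compounds and their values:
- compound 1, `CCCCCCCc1cc2cn(COCCO)c(=O)nc2o1`, gives 400000 nM in a functional assay on HEL cells (Homo sapiens), read by microscopy; a lower number here means that less compound is tolerated, a higher number that more compound is tolerated
- compound 2, `CCCCCCCCCc1cc2cn(COCCO)c(=O)nc2o1`, gives >= 16000 nM in this assay; this is a limit of the assay, not a number
- compound 3, `CCCCCCCCCCc1cc2cn(COCCO)c(=O)nc2o1`, gives 400000 nM in this assay

Compound 3 stands level with compound 1 at the digits shown, the step of no change at the digits printed from compound 1 to compound 3 (within the scatter) lying within the scatter. The limit for compound 2 is noted as the limit of >= 16000 nM in this assay, at which 1 of the 3 values shown sits, so the steps a step that the limit leaves unreadable from compound 1 to compound 2 and a step that the limit leaves unreadable from compound 2 to compound 3 cannot be sized.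

Compound 4, `CCCCCCCCc1cc2cn(COCCO)c(=O)nc2o1`, is not yet measured. It differs from compound 3 by hydrogen in place of ethyl on a saturated chain carbon, eight bonds along the chain from an aromatic carbon. Going by the values given here, the only readable step among the measured compounds, from compound 1 to compound 3, shows no change, and the two steps through compound 2 give no size. No step beyond the scatter is therefore expected for compound 4, though its value may again come out as a limit. Compound 4 is estimated to give 400000 nM, between 100000 nM and 400000 nM, meaning an expected step of no change at the digits printed from compound 3 to compound 4 (within the scatter).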

Compound 4, minimum cytotoxic concentration: >= 80000 nM
Compound 4 gave a limit, no number (the forecaster's own chance of this, stated with the estimate: 40%); the middle value is on the limit's open side.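

Compound 4 gives only a limit in this assay, not a number, so no new step can be read between it and compound 1, compound 2 or compound 3. The compounds shown leave open whether compound 2 and compound 4 actually stand level with compound 1 and compound 3.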